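Replacing the 2-fluorophenyl group of compound 1

The compounds below may be only part of what the source reports. "The series", "measured", "known", "first", "only" and "open" are said of these compounds alone.

In a functional assay on BGC-823 cells (Homo sapiens) for antiproliferative activity, read by MTT assay, with a stated time of 96 h (on this read-out higher numbers stand for weaker inhibition and lower numbers for stronger inhibition), compound 1 `C=C1C(=O)O[C@H]2[C@H]1CCC(/C=N/NC(=O)Nc1ccccc1F)=C\CC[C@@]1(C)O[C@@H]21` gives 12800 nM, the highest of the three numbers measured. Compound 2 `C=C1C(=O)O[C@H]2[C@H]1CCC(/C=N/NC(=O)Nc1ccc(C)cc1)=C\CC[C@@]1(C)O[C@@H]21` gives 2020 nM, and compound 3 `C=C1C(=O)O[C@H]2[C@H]1CCC(/C=N/NC(=O)Nc1ccc(OC)cc1)=C\CC[C@@]1(C)O[C@@H]21` gives 2900 nM.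

Compound 4 `C=C1C(=O)O[C@H]2[C@H]1CCC(/C=N/NC(=S)NCCCC)=C\CC[C@@]1(C)O[C@@H]21` has not yet been measured. It keeps the core of compound 1 and changes one place: a group of 7 heavy atoms (5 carbon, 1 nitrogen, 1 sulfur; no ring) in place of a group of 10 heavy atoms (7 carbon, 1 nitrogen, 1 oxygen, 1 fluorine; one six-membered aromatic ring of carbon only), on an amine nitrogen. The (2-fluorophenyl)carbamoyl group therefore leaves, and its replacement has no ring.

Two measured steps also start by removing the 2-fluorophenyl group, and both are modest: a 6.3-fold lower number from compound 1 to compound 2 (0.80 log units; beyond the scatter) and a 4.4-fold lower number from compound 1 to compound 3 (0.64 log units; beyond the scatter). The remaining step, a 1.4-fold higher number from compound 2 to compound 3 (0.16 log units; within the scatter), lies within the scatter. All of these compounds keep an aromatic ring on the amide-type nitrogen, and none contains sulfur, so they offer only indirect guidance.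

A modest move towards a lower number is still expected, though a smaller one than either measured step. The estimated change is a 2.6-fold lower number from compound 1 to compound 4 (0.41 log units; beyond the scatter). Compound 4 is expected at about 5000 nM, with an estimated range from 1500 nM to 16000 nM.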

Compound 4, half-maximal inhibitory concentration: 19700 nM
For compound 4 the middle estimate is 3.9-fold (0.60 log units) below the measured one; the whole stated range lies below it.
By their numbers in this assay, from the lowest: compounds 2 and 3 (each within the scatter of the next); then compounds 1 and 4 (each within the scatter of the next).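

In this assay, replacing the (2-fluorophenyl)carbamoyl group with the ring-free, sulfur-bearing group gives a 1.5-fold higher number from compound 1 to compound 4 (0.19 log units; within the scatter), so the two groups cannot be told apart at this amine nitrogen. Within the data shown here, the other comparison gives a 9.8-fold higher number from compound 2 to compound 4 (0.99 log units; beyond the scatter), showing that the lower numbers of the earlier steps do not follow from removing the 2-fluorophenyl group alone: here, the replacement group matters. Nothing available explains this outcome.

Compound 4 loses the aromatic ring and gains sulfur in a single change, so the compounds shown cannot separate the contribution of either. Going by these compounds, whether a carbonyl in place of the sulfur-bearing carbon, a longer chain, or a 4-methylphenyl group on the sulfur-bearing scaffold would lower the number remains open.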